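This account rests on a few compounds, and the source may have more. Where it says the series, first, only, none or still open, it means among the compounds named here.

compound 1 `CCC(OC(=O)N[C@@H](CCC(=O)C=[N+]=[N-])C(=O)OC)OC(=O)C(C)(C)C`: 75%
compound 2 `CCOC(=O)[C@H](CCC(=O)C=[N+]=[N-])NC(=O)OCc1oc(=O)oc1C`: 0%
compound 3 `Cc1oc(=O)oc1COC(=O)N[C@@H](CCC(=O)C=[N+]=[N-])C(=O)OC(C)C`: 0%

These values come from an ADME assay on a cell-free system (plasma, Macaca mulatta) for metabolic stability, read by LC-MS, with a stated time of 60 min, tested at 10 uM; on this read-out lower numbers stand for a less stable compound and higher numbers for a more stable compound. Compound 1 gives 75%, the highest of the three, and its gaps to the other two compounds lie beyond the scatter. Compound 4 `COC(=O)[C@H](CCC(=O)C=[N+]=[N-])NC(=O)OC(OC(=O)C(C)(C)C)C(C)C` differs from compound 1 as follows: methyl in place of hydrogen on a saturated chain carbon bound to two saturated chain carbons. Read one bond further out, this is ethyl to isopropyl. Among the measured compounds shown here, the only measured step of this kind is no change at the digits printed from compound 2 to compound 3 (within the scatter). That methyl sits at a different place, on a saturated chain carbon bound to an oxygen next to a carbonyl group and a saturated chain carbon. Compound 2 gives 0% and compound 3 gives 0%, so this step offers little guidance for a compound that retains as much as compound 1 does. The data give no firm direction for the new methyl. The estimated step is no change at the digits printed from compound 1 to compound 4 (within the scatter), and it is not expected to exceed the scatter. Compound 4 is expected at 75%, with an estimated range of 50% to 92%.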

Compound 4, percent of the compound remaining: 61%
Beside the measured number, compound 4's estimate is 14 percentage points above it; low and high end bracket the measured number.
By their numbers in this assay, from the lowest: compounds 2 and 3 (each within the scatter of the next); then compound 4; then compound 1.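

In this assay, ethyl to isopropyl, a methyl in place of hydrogen on a saturated chain carbon bound to two saturated chain carbons, gives a number 14 percentage points lower from compound 1 to compound 4 (beyond the scatter), so this position responds to the added methyl, though the step is modest and compound 4 keeps a sizeable share of the parent. The earlier methyl step could not show such a response, since compound 2 gives 0% and compound 3 gives 0%, leaving no room for a further fall. The two methyl steps still cannot be told apart as sizes: the same change on two cores in this assay, no change at the digits printed (within the scatter) from compound 2 to compound 3 and a number 14 percentage points lower (beyond the scatter) from compound 1 to compound 4, 14 percentage points apart, within the scatter of two such steps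

Open, going by these compounds, is how a propyl chain, a tert-butyl group or a cyclopropyl ring on this carbon would read in this assay. Also open, on these data alone, is whether ethyl to isopropyl gives a step of similar size on any other core that stays measurable in this read-out.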